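A few compounds are considered here, and "the series" means these few. Any claim that something is new, unique, unknown or untested is made for them only; others in the source may bear on it.

Compound 2 `Nc1ccc(-c2cc(=O)c3c(N)cccc3o2)cc1` carries an amino group on the shared core and no chloro; in a functional assay on MCF7 cells (Homo sapiens) for inhibition, in the absence of a further agent (on this read-out lower numbers stand for stronger inhibition and higher numbers for weaker inhibition), compound 2 gives 7.3 nM. For the measured compounds named here, of the two numbers measured so far this is the higher one, although compound 1 `Nc1ccc(-c2cc(=O)c3c(N)c(Cl)ccc3o2)cc1`, which bears a chloro on the core and gives 3.9 nM, sits within the scatter of it.

Compound 3 `Nc1ccc(-c2cc(=O)c3c(N)ccc(Cl)c3o2)cc1` is not yet measured. Going by the values given here, its difference from compound 2 is chloro in place of hydrogen on an aromatic carbon, the chloro entering at a different place on the same ring from the one where compound 1 carries its chloro.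

Among the compounds with values here, only one measured step speaks to this: a 1.9-fold higher number from compound 1 to compound 2 (0.27 log units; within the scatter). Taking a chloro off that ring at another place thus changed the number by an amount that could be mere scatter, and there is no measured example of a chloro at the new place, para to the amino group. A step of similarly small size is therefore expected from compound 2 to compound 3, if anything towards a lower number, namely a 1.5-fold lower number from compound 2 to compound 3 (0.16 log units; within the scatter). Compound 3 is estimated at 5 nM, most likely between 2 nM and 13 nM.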

Compound 3, half-maximal inhibitory concentration: 9.8 nM
Compound 3: the middle estimate sits 2.0-fold (0.29 log units) below what was measured, within the range that was stated.
By their numbers in this assay, from the lowest: compounds 1, 2 and 3 (each within the scatter of the next, the first and the last beyond it).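

Placing a chloro para to an amino group on the shared core gives a 1.3-fold higher number from compound 2 to compound 3 (0.13 log units; within the scatter) in this assay, so this position accepts the chloro without a change that can be told apart from repeat-to-repeat variation. The earlier compounds shown here showed this only for the chloro of compound 1, and the step of a 1.9-fold higher number from compound 1 to compound 2 (0.27 log units; within the scatter) is also within the scatter, so the chloro has now been seen at two places on this ring and neither step on its own counts as a real gain or loss. No supporting measurement is available that could explain why this replacement of hydrogen by chloro leaves the number so little moved.

The compounds shown speak only of chloro and hydrogen at this place, so it remains open whether a fluoro, a methoxy, a carboxylic acid or a longer chain there would produce a step beyond the scatter. Also open, as far as these compounds go, is whether the same small effect would hold in a compound lacking the amino group that this chloro sits para to, since every compound here carries it.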